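From methoxy to trifluoromethyl at a solubility limit

This account rests on a few compounds, and the source may have more. Where it says the series, first, only, none or still open, it means among the compounds named here.

Measured so far in a physicochemical assay for solubility, using the shake flask method, in simulated intestinal fluid, measured as kinetic solubility, with a stated time of 2 h, at 25 degrees C, at pH 6.5; on this read-out higher numbers stand for higher solubility and lower numbers for lower solubility:
- Compound 1 `Cc1noc(-c2nc(C)c3c(c2N)C(=O)N(Cc2ccc(Cl)cc2)C3=O)n1`: < 5000 nM
- Compound 2 `COc1ccc(CN2C(=O)c3c(C)nc(-c4nc(C)no4)c(N)c3C2=O)cc1`: < 5000 nM

Compound 2 stands at < 5000 nM, which is a limit and not a number. Nothing firmer is available than the limit of < 5000 nM in this assay, at which 2 of the 2 values shown sit.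

Compound 3 `Cc1noc(-c2nc(C)c3c(c2N)C(=O)N(Cc2ccccc2C(F)(F)F)C3=O)n1` has 2-(trifluoromethyl)phenyl in place of 4-methoxyphenyl on a saturated chain carbon bound to an amide-type nitrogen in a ring.

For the measured compounds named here, the only measured step is a step that the two limits leave unreadable from compound 1 to compound 2, a swap of methoxy for chloro on an aromatic carbon. With only a step that the two limits leave unreadable from compound 1 to compound 2 to go on, no step beyond the scatter is expected in this assay, and no direction can be expected either. Compound 3 will probably be reported as a limit too. The expected step is a step that the limit leaves unreadable from compound 2 to compound 3. For compound 3 the estimated value is 2500 nM, with an expected range from 700 nM to 5000 nM.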

Compound 3, solubility: < 5000 nM
Compound 3 gave a limit, no number; the forecaster's own chance of this, stated with the estimate: 85%; the middle value lies beyond the limit too.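

Compound 3 also gives a limit and not a number, so in this assay no step can be read from compound 2 to compound 3 or from compound 1 to compound 3: the limit of < 5000 nM in this assay, at which 3 of the 3 values shown sit. The compounds shown leave open how soluble each one actually is, and whether swapping these groups on the shared core changes solubility at all.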